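Chloro on the Phenyl Ring and Paw Edema Inhibition

A few compounds are considered here, and "the series" means these few. Any claim that something is new, unique, unknown or untested is made for them only; others in the source may bear on it.

Measured compounds:
compound 1, `Cn1c(SCC(=O)Nn2c(COc3ccc(Cl)cc3Cl)nc3ccccc3c2=O)nc(-c2ccccc2)c(C#N)c1=O`, 59.7%
compound 2, `Cn1c(SCC(=O)Nn2c(COc3ccc(Cl)cc3Cl)nc3ccccc3c2=O)nc(-c2ccc(Cl)cc2)c(C#N)c1=O`, 73.7%
compound 3, `N#Cc1c(Nc2ccccc2)nc(SCC(=O)Nn2c(COc3ccc(Cl)cc3Cl)nc3ccccc3c2=O)nc1-c1ccccc1`, 78.1%

All three were tested in a functional assay on the whole organism (strain albino) for inhibition, with Rattus norvegicus as the target, read by paw edema, with stated times of 1 h and 2 h, at a dose of 100 mg/kg by the oral route; a lower number here means less inhibition, a higher number more inhibition at the dose given (going by the name of the read-out). Compound 1 and compound 2 share one core, and the single difference between them is chloro in place of hydrogen on an aromatic carbon. That change gave a number 14 percentage points higher from compound 1 to compound 2 (beyond the scatter). Compound 3 carries a different core; the difference between the two cores is not broken down here. In this assay compound 3 gives a number that lies within the usual scatter of the number for compound 2, so no order between the two can be stated, while its number stands above that of compound 1 by more than the scatter.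

Compound 4, `N#Cc1c(Nc2ccccc2)nc(SCC(=O)Nn2c(COc3ccc(Cl)cc3Cl)nc3ccccc3c2=O)nc1-c1ccc(Cl)cc1`, has not yet been measured. It differs from compound 3 by chloro in place of hydrogen on an aromatic carbon, the same change as that between compound 1 and compound 2, at the same place. On the strength of that one earlier step, a gain of similar or somewhat smaller size is expected from compound 3 to compound 4, namely a number 5.9 percentage points higher from compound 3 to compound 4 (within the scatter). Compound 4 is therefore estimated at 84% in this assay, expected to fall between 73% and 93%.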

Compound 4, a percentage reported as inhibition, in the whole organism at one dose (the size of the read-out at that dose, not a potency): 50.9%
Beside the measured number, compound 4's estimate is 33.1 percentage points above it, outside the stated range (below it).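

Moving from phenyl to 4-chlorophenyl on the core of compound 3 did not repeat the gain seen on the other core: in this assay the change gave a number 27.2 percentage points lower from compound 3 to compound 4 (beyond the scatter). Set beside the earlier step, the two results run in opposite directions and clearly differ: the same change on two cores in this assay, a number 14 percentage points higher (beyond the scatter) from compound 1 to compound 2 and a number 27.2 percentage points lower (beyond the scatter) from compound 3 to compound 4, 41.2 percentage points apart, beyond the scatter of two such steps This shows that, for these two pairs, neither the size nor the direction of the chloro step carried over from one core to the other, but it does not show which part of the difference between the cores is responsible, nor does it give a rule for any further core.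

The compounds shown leave open how a fluoro, a methoxy group or an amine in place of the chloro would behave on each of the two cores. They also leave open whether the opposite steps would persist at other doses of the same whole-animal test.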